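Ethoxy to trifluoromethoxy on a weakly active compound

The compounds below may be only part of what the source reports. "The series", "measured", "known", "first", "only" and "open" are said of these compounds alone.

In a functional assay on A-375 cells (Homo sapiens) for antiproliferative activity, read by MTT assay, with a stated time of 24 h (a lower number here means a stronger inhibitor, a higher number a weaker inhibitor), compound 1 (`CCc1ccc2nc(C(=O)Nc3c(F)cc(-c4cccc(F)c4)cc3F)c(C)c(O)c2c1`) gives 8130 nM. Compound 2 (`CCOc1ccc2nc(C(=O)Nc3c(F)cc(-c4cccc(F)c4)cc3F)c(C)c(O)c2c1`) gives > 100000 nM, which is a limit of the assay and not a number, so it is known only to lie at the weak end of the scale.

The next compound, compound 3 (`Cc1c(C(=O)Nc2c(F)cc(-c3cccc(F)c3)cc2F)nc2ccc(OC(F)(F)F)cc2c1O`), keeps the shared core and alters one group. The change is trifluoromethyl in place of ethyl on an oxygen on an aromatic ring, or ethoxy to trifluoromethoxy.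

Among the compounds with values here, only one measured step bears on this. It is an at least 12-fold higher number from compound 1 to compound 2 (1.08 log units; beyond the scatter), a large step that came with ethoxy in place of ethyl on an aromatic carbon. Compound 3 keeps the oxygen that entered in that step, so it is expected to stay weak in this assay, with at best a modest move towards a lower number and a real chance of another limit. The expected step is an at least 2.5-fold lower number from compound 2 to compound 3 (0.39 log units; beyond the scatter). For compound 3 the estimated value is 40000 nM, with an expected range from 10000 nM to 100000 nM.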

Compound 3, half-maximal inhibitory concentration: 38300 nM
Beside the measured number, compound 3's estimate is 1.0-fold (0.02 log units) above it; the range from low to high includes it.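

In this assay the swap of ethyl for trifluoromethyl on the oxygen gives an at least 2.6-fold lower number from compound 2 to compound 3 (0.41 log units; beyond the scatter) and lifts the compound off the weak end of the scale, so an oxygen at this place does not by itself abolish the activity; what sits on that oxygen also counts. The oxygen-bearing compound still does not get back to the plain ethyl group on the aromatic carbon, as a 4.7-fold higher number from compound 1 to compound 3 (0.67 log units; beyond the scatter) shows, and so of these three groups the ethyl of compound 1 keeps the lowest number. The gain from compound 2 can be given only as a minimum, not an exact size, because compound 2 is a limit of the assay and not a number: the limit of > 100000 nM in this assay, at which 1 of the 3 values shown sits.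

The compounds shown leave open how a methoxy group, a longer chain on the oxygen or an amine on the same aromatic carbon would behave in this assay, and whether any group here can go lower than ethyl. They also cannot tell why trifluoromethyl and ethyl on the oxygen differ, as they give only activity on cells and no other measured property.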